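The source may report more compounds than this note shows. Statements on the series, on what has been measured and on what is new or still open speak of the compounds shown alone.

Working notes on the series in an assay on CHO cells for antagonist activity at transient receptor potential cation channel subfamily V member 1 (Homo sapiens), read by FLIPR; a lower number here means a stronger inhibitor, a higher number a weaker inhibitor.

Compound 1 `CC(C(=O)NCc1ccc(C(F)(F)F)nc1-c1ccc(Cl)c(Cl)c1)c1ccc(NS(C)(=O)=O)c(F)c1` gives 0.9 nM in this assay. Compound 2 `CC(C(=O)NCc1ccc(C(F)(F)F)nc1-c1ccoc1)c1ccc(NS(C)(=O)=O)c(F)c1` gives 1.4 nM in this assay. Across these two numbers compound 2 and compound 1 lie within the scatter of each other, so no order between them can be read; the single measured step is a 1.6-fold higher number from compound 1 to compound 2 (0.19 log units; within the scatter).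

Compound 3 `CC(C(=O)NCc1ccc(C(F)(F)F)nc1CCc1ccc(F)cc1)c1ccc(NS(C)(=O)=O)c(F)c1` is not yet measured. It differs from compound 2 in one place: 2-(4-fluorophenyl)ethyl in place of furan-3-yl on an aromatic carbon. For the measured compounds named here, the only step that bears on this position is a 1.6-fold higher number from compound 1 to compound 2 (0.19 log units; within the scatter), which shows the group on this carbon was tolerated across two rather different choices. The new group has no ring directly on the core carbon, so that step is an imperfect guide and the range must stay wide. The expected step of a 2.1-fold higher number from compound 2 to compound 3 (0.33 log units; beyond the scatter) is a modest rise, not clearly beyond the scatter. Compound 3 is therefore estimated at 3 nM, with a range from 0.7 nM to 12 nM.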

Compound 3, inhibition constant: 1.8 nM
For compound 3 the middle estimate is 1.7-fold (0.22 log units) above the measured one; measured number inside the range.
By their numbers in this assay, from the lowest: compounds 1, 2 and 3 (each within the scatter of the next).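

In this assay, the aromatic carbon next to the ring nitrogen now also accepts a group with no ring directly on it: 2-(4-fluorophenyl)ethyl in place of furan-3-yl gives a 1.3-fold higher number from compound 2 to compound 3 (0.11 log units; within the scatter), and in place of 3,4-dichlorophenyl it gives a 2.0-fold higher number from compound 1 to compound 3 (0.30 log units; within the scatter). Both steps stay within the scatter, so no order among the three groups can be read, and a directly attached ring is not needed at this carbon for a number in this range. No measurement on hand explains this result.

On these data alone, it remains open whether an amine or a carboxylic acid on this carbon would give a step beyond the scatter. The compounds shown also do not separate the contribution of the 4-fluoro substituent from that of the two-carbon link, which an unsubstituted 2-phenylethyl group or a longer chain could address.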